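Chloro in Place of Hydrogen, Tested in Two Settings

This account rests on a few compounds, and the source may have more. Where it says the series, first, only, none or still open, it means among the compounds named here.

Compound 1 `O=C(CCCCC(S)CCS)Nc1ccccc1` and compound 2 `O=C(CCCCC(S)CCS)Nc1ccc(Cl)cc1` differ by one change: chloro in place of hydrogen on an aromatic carbon. In a functional assay on HO8910 cells (Homo sapiens) for inhibition, read by MTT assay, with a stated time of 24 h, tested at 1 ug/mL (a lower number here means less inhibition of growth, a higher number more inhibition of growth at the concentration tested), compound 1 gives 6.38%, and compound 2 gives 2.81%; the step is a number 3.6 percentage points lower from compound 1 to compound 2 (within the scatter). Compound 3 `O=C(CCCCC(CCSC(=O)c1ccccc1)SC(=O)c1ccccc1)Nc1ccccc1` rests on another core; the difference between the two cores is not broken down here. In this assay compound 3 gives 3.79%. Compound 4 `O=C(CCCCC(CCSC(=O)c1ccccc1)SC(=O)c1ccccc1)Nc1ccccc1Cl` carries the same kind of change as that pair: chloro in place of hydrogen on an aromatic carbon. The surroundings differ, though: in compound 2 the chloro sits para to a large group, in compound 4 ortho to a large group. Compound 4 is expected to move by about a number 0.3 percentage points lower from compound 3 to compound 4 (within the scatter) because the earlier step of a number 3.6 percentage points lower from compound 1 to compound 2 (within the scatter) lay within the scatter. Compound 4 is estimated at 3.5%, between -3% and 10%.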

Compound 4, percent growth inhibition at one concentration: 2.35%
Compound 4: the middle estimate sits 1.2 percentage points above what was measured; the range from low to high includes it.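

In this assay, chloro in place of hydrogen on the aromatic ring gives a number 1.4 percentage points lower from compound 3 to compound 4 (within the scatter). Set beside the earlier step, the result on the second core does not differ from the result on the first: the same change on two cores in this assay, a number 3.6 percentage points lower (within the scatter) from compound 1 to compound 2 and a number 1.4 percentage points lower (within the scatter) from compound 3 to compound 4, 2.1 percentage points apart, within the scatter of two such steps. This shows that the change left no readable mark on either core at the single concentration tested, but with both steps within the scatter, it does not show that any real effect carries from one core to the other, and the chloro also sits in a different place in compound 2 and compound 4.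

As far as these compounds go, whether chloro at one shared place would behave alike on both cores stays open. So does whether a different ring substituent, such as an amine or a carboxylic acid, would shift growth inhibition beyond the scatter.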